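Phenyl to cyclopropyl on the amide-type nitrogen

The compounds below may be only part of what the source reports. "The series", "measured", "known", "first", "only" and "open" are said of these compounds alone.

In a functional assay on HCT-116 cells (Homo sapiens) for antiproliferative activity, read by MTT assay, with a stated time of 72 h (a higher number here means a weaker inhibitor, a lower number a stronger inhibitor), compound 3 (`O=C1COc2ccc(-c3cnc(Cl)c(NS(=O)(=O)c4ccc(F)cc4)c3)cc2N1c1ccccc1`) gives 39800 nM. Compound 2 (`COc1ncc(-c2ccc3c(c2)N(C2CC2)C(=O)CO3)cc1NS(=O)(=O)c1ccc(F)cc1`) gives 24300 nM, within the scatter of compound 3. Compound 1 (`CC(C)N1C(=O)COc2ccc(-c3cnc(Cl)c(NS(=O)(=O)c4ccc(F)cc4)c3)cc21`) gives 18900 nM, beyond the scatter of compound 3.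

Compound 4 (`O=C1COc2ccc(-c3cnc(Cl)c(NS(=O)(=O)c4ccc(F)cc4)c3)cc2N1C1CC1`) has not yet been measured. It carries cyclopropyl in place of phenyl on an amide-type nitrogen in a ring. Going by the values given here, the only measured step at this place is a 2.1-fold higher number from compound 1 to compound 3 (0.32 log units; beyond the scatter), a modest one with phenyl in place of isopropyl. Compound 2 also has cyclopropyl on this nitrogen but differs from compound 4 in another place, so it is only a loose guide. A step to a lower number in this assay is therefore expected, no larger than about the size of the step from isopropyl to phenyl. The expected step is a 1.9-fold lower number from compound 3 to compound 4 (0.28 log units; within the scatter). The estimated value for compound 4 is 21000 nM, with an expected range of 10000 nM to 42000 nM.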

Compound 4, half-maximal inhibitory concentration: 12400 nM
The estimate for compound 4 lay 1.7-fold (0.23 log units) above the measured number; the measured number falls inside the stated range.
By their numbers in this assay, from the lowest: compounds 4, 1, 2 and 3 (each within the scatter of the next, the first and the last beyond it).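

Going by these compounds alone, at the amide-type nitrogen, the direct change from phenyl to cyclopropyl in this assay gives a 3.2-fold lower number from compound 3 to compound 4 (0.51 log units; beyond the scatter), a step beyond the scatter and larger than the one the earlier compounds showed at this place. Cyclopropyl and isopropyl are not separated at this nitrogen, with a 1.5-fold lower number from compound 1 to compound 4 (0.18 log units; within the scatter), so among these three groups only phenyl stands apart, on the higher side. With cyclopropyl held fixed, chloro in place of methoxy on the aromatic carbon gives a 2.0-fold lower number from compound 2 to compound 4 (0.29 log units; within the scatter), which is within the scatter, so this pair shows no clear effect of that change.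

No measurement at hand explains these steps. As far as these compounds go, it remains open how a methyl group, a longer alkyl chain or a chain ending in an amine would read on this nitrogen.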